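Adding one methyl to compound 3

A few compounds are considered here, and "the series" means these few. Any claim that something is new, unique, unknown or untested is made for them only; others in the source may bear on it.

In a functional assay on SMMC-7721 cells (Homo sapiens) for cytotoxicity, read by MTT assay, with a stated time of 24 h (a lower number here means a stronger inhibitor, a higher number a weaker inhibitor), compound 1 `Cc1ccc(S(=O)(=O)N2C/C(=C\c3ccncc3)C(=O)/C(=C/c3ccccc3F)C2)cc1` gives 13200 nM and compound 2 `Cc1ccc(S(=O)(=O)N2C/C(=C\c3cccnc3)C(=O)/C(=C/c3ccccc3C(F)(F)F)C2)cc1` gives 6700 nM while compound 3 `O=C1/C(=C/c2ccncc2)CN(S(=O)(=O)c2ccccc2)C/C1=C\c1ccccc1C(F)(F)F` gives 6540 nM so all three sit within the usual scatter of one another, and compound 3 cannot be told apart from either. Compound 4 `Cc1ccc(S(=O)(=O)N2C/C(=C\c3ccncc3)C(=O)/C(=C/c3ccccc3C(F)(F)F)C2)cc1` differs from compound 3 by one change (methyl in place of hydrogen on an aromatic carbon) with methyl in place of hydrogen on an aromatic carbon, turning phenylsulfonyl into (4-methylphenyl)sulfonyl. Going by the values given here, no measured pair shows this change alone, but compound 2 already carries that methyl and gives 6700 nM here, so no shift beyond the scatter is expected. The expected change is a 1.0-fold higher number from compound 3 to compound 4 (0.02 log units; within the scatter) and stays within the scatter. In this assay the estimate for compound 4 is 6800 nM with 3500 nM to 13000 nM as the expected range.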

Compound 4, half-maximal inhibitory concentration: 5590 nM
Beside the measured number, compound 4's estimate is 1.2-fold (0.09 log units) above it; the range from low to high includes it.
By their numbers in this assay, from the lowest: compounds 4, 3, 2 and 1 (each within the scatter of the next, the first and the last beyond it).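

Read directly for the first time in this assay, the methyl on the phenylsulfonyl ring gives a 1.2-fold lower number from compound 3 to compound 4 (0.07 log units; within the scatter) and so has no effect that can be told from the scatter. Pyridin-4-yl in place of pyridin-3-yl likewise gives a 1.2-fold lower number from compound 2 to compound 4 (0.08 log units; within the scatter) while trifluoromethyl in place of fluoro gives a 2.4-fold lower number from compound 1 to compound 4 (0.37 log units; beyond the scatter) and is the only step here to clear the scatter, if modestly. Nothing measured here explains these steps. As far as these compounds go, whether an amine, a methoxy group or a carboxylic acid at this same ring carbon would shift the number remains open.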